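This account rests on a few compounds, and the source may have more. Where it says the series, first, only, none or still open, it means among the compounds named here.

Compound 1 `CC1(C)C[C@@H](CN([C@H](CCC(F)(F)F)C(N)=O)S(=O)(=O)c2ccc(Cl)cc2)O1` gives 3.8 in a physicochemical assay for lipophilicity, read by HPLC, measured as octanol-water partition, at pH 7.4; a higher number here means a more lipophilic compound, a lower number a more polar compound; compound 2 `CC1(C)CO[C@@H]1CN([C@H](CCC(F)(F)F)C(N)=O)S(=O)(=O)c1ccc(Cl)cc1` gives 3.9; compound 3 `NC(=O)[C@@H](CCC(F)(F)F)N(C[C@@H]1CCCCO1)S(=O)(=O)c1ccc(Cl)cc1` gives 4.3.

Compound 1 holds the lowest number of the three: compound 2 stands nearest, a number 0.10 log units higher from compound 1 to compound 2 (within the scatter), and compound 3 furthest, a number 0.50 log units higher from compound 1 to compound 3 (beyond the scatter). Compound 4 `NC(=O)[C@@H](CCC(F)(F)F)N(C[C@@H]1CCO1)S(=O)(=O)c1ccc(Cl)cc1` differs from compound 1 as follows: oxetan-2-yl in place of 4,4-dimethyloxetan-2-yl on a saturated chain carbon bound to a sulfonamide nitrogen. Among the compounds with values here, no measured step removes two methyl groups; the steps in hand only move the methyl groups or swap the ring, giving a number 0.10 log units higher from compound 1 to compound 2 (within the scatter) and a number 0.40 log units higher from compound 2 to compound 3 (beyond the scatter). Losing the methyl groups is expected to lower the number in this assay, beyond the scatter. The estimate for compound 4 is 2.9, between 2.5 and 3.4, an expected a number 0.90 log units lower from compound 1 to compound 4 (beyond the scatter).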

Compound 4, distribution coefficient: 2.6
Compound 4: middle estimate off by 0.30 log units, on the high side, within the range that was stated.
By their numbers in this assay, from the lowest: compound 4; then compounds 1 and 2 (each within the scatter of the next); then compound 3.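

Within the data shown here, at this place, on a saturated chain carbon bound to a sulfonamide nitrogen, this assay shows large steps for the first time: removing the two methyl groups gives a number 1.20 log units lower from compound 1 to compound 4 (beyond the scatter) and a number 1.30 log units lower from compound 2 to compound 4 (beyond the scatter) whichever dimethyl pattern leaves. The change from oxan-2-yl to oxetan-2-yl gives a number 1.70 log units lower from compound 3 to compound 4 (beyond the scatter) as the widest step shown. No evidence at hand gives a cause for these steps.

The compounds shown leave open whether a single methyl group on the oxetan-2-yl ring would land part way along this step. They also leave open how an amine at this place would read.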